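The source may hold more compounds than are shown below. What is called first, only, known or untested is meant among the compounds shown, and "the series" means these compounds.

In an ADME assay on cells for inhibition of Intestinal-type alkaline phosphatase (Homo sapiens), read by luminescence, with stated times of 7 min and 20 min (on this read-out lower numbers stand for stronger inhibition and higher numbers for weaker inhibition), compound 1, `C=CCNc1nn2c(=O)cc(C(F)(F)F)nc2s1`, gives 890 nM, the higher of the two numbers that are shown here. Compound 2, `CCCNc1nn2c(=O)cc(C(F)(F)F)nc2s1`, gives 310 nM in this assay, and the step of a 2.9-fold lower number from compound 1 to compound 2 (0.46 log units; beyond the scatter) is a modest one. Compound 3, `COc1ccccc1-c1nn2c(=O)cc(C(F)(F)F)nc2s1`, is reported in this assay only as a limit, > 100000 nM, and not as a number. That limit is the one at the limit of > 100000 nM in this assay, at which 1 of the 3 values shown sits.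

Compound 4, `O=c1cc(C(F)(F)F)nc2sc(-c3ccccc3F)nn12`, has not yet been measured in this assay. It differs from compound 1 in one place: 2-fluorophenyl in place of allylamino on an aromatic carbon. Going by the values given here, the only measured step, from compound 1 to compound 2, touches just the chain of the allylamino group and keeps the nitrogen; it offers little guidance on exchanging the whole group for an aryl ring. The nearer guide is compound 3, whose 2-methoxyphenyl group stands in for the amino group and which reaches only the limit of this assay. On that basis compound 4 is expected to show a large loss, a 90-fold higher number from compound 1 to compound 4 (1.95 log units; beyond the scatter). The value of compound 4 in this assay is estimated at 80000 nM, in a range from 15000 nM to 400000 nM, with a real chance that only a limit is reported.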

Compound 4, half-maximal inhibitory concentration: > 100000 nM
Compound 4 ended at the assay's limit (the forecaster's own chance of this, stated with the estimate: 55%); at least 1.2-fold (0.09 log units) between middle value and limit.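

In this assay compound 4 is reported only as a limit, > 100000 nM. Putting 2-fluorophenyl on this aromatic carbon in place of allylamino gives an at least 110-fold higher number from compound 1 to compound 4 (2.05 log units; beyond the scatter), and putting it there in place of propylamino gives an at least 320-fold higher number from compound 2 to compound 4 (2.50 log units; beyond the scatter), so the large loss is now seen against both amino compounds and not only against one of them. Compound 3 had been a single case, but with fluoro in place of methoxy on the aryl ring the result stays the same, and at this position both aryl compounds, compound 3 and compound 4, reach the limit while neither amino compound, compound 1 or compound 2, does: the limit of > 100000 nM in this assay, at which 2 of the 4 values shown sit.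

Since compound 3 and compound 4 are both limits, the step between them cannot be read, and nothing can be said about fluoro against methoxy. Also open, on these data alone, is whether the loss follows the aryl ring itself or the absence of the amino nitrogen, a question that a benzylamino or anilino group, carrying a ring on that nitrogen, would address, as is how far a longer chain such as butylamino would carry the trend from allylamino to propylamino.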